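Ester in place of ether chain: compound 3 expected

A few compounds are considered here, and "the series" means these few. Any claim that something is new, unique, unknown or untested is made for them only; others in the source may bear on it.

Measured so far:
Compound 1, `COC(C)CO[C@H](CC=C(C)C)C1=CC(=O)c2c(O)ccc(O)c2C1=O`, gives 16600 nM in a functional assay on DU-145 cells (Homo sapiens) for cytotoxicity, read by MTT assay; a lower number here means a stronger inhibitor, a higher number a weaker inhibitor.
Compound 2, `CCC(CO[C@H](CC=C(C)C)C1=CC(=O)c2c(O)ccc(O)c2C1=O)OC(C)=O`, gives 25400 nM in this assay.

Compound 2 holds the higher of the two numbers, but its nearest neighbour is compound 1, and the step of a 1.5-fold higher number from compound 1 to compound 2 (0.18 log units; within the scatter) falls within the scatter, so no order between the two is claimed. Compound 3, `CC(C)=CC[C@@H](OC(=O)C1CCCOC1)C1=CC(=O)c2c(O)ccc(O)c2C1=O`, differs from compound 2 in one place: (oxan-3-yl)carbonyl in place of 2-acetoxybutyl on an oxygen on a saturated carbon. Going by the values given here, the only measured step, a 1.5-fold higher number from compound 1 to compound 2 (0.18 log units; within the scatter), swapped one chain for another on that same oxygen and stayed within the scatter; no measured step exchanges a chain there for a ring-bearing carbonyl, so nothing in the data points to a direction. Compound 3 is therefore expected to give about 20000 nM in this assay, within 6000 nM to 70000 nM. The step of a 1.3-fold lower number from compound 2 to compound 3 (0.10 log units; within the scatter) that this estimate means is expected to stay within the scatter.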

Compound 3, half-maximal inhibitory concentration: 29700 nM
Compound 3: middle estimate off by 1.5-fold (0.17 log units), on the low side; low and high end bracket the measured number.
By their numbers in this assay, from the lowest: compounds 1, 2 and 3 (each within the scatter of the next).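

On the oxygen on a saturated carbon, the exchange of an open chain for a ring-bearing carbonyl had not been tested by the earlier pair, and in this assay it gives a 1.2-fold higher number from compound 2 to compound 3 (0.07 log units; within the scatter) and, against the 2-methoxypropyl chain, a 1.8-fold higher number from compound 1 to compound 3 (0.25 log units; within the scatter) as well. Both steps lie within the scatter, so this place accepts (oxan-3-yl)carbonyl as readily as either chain, and the three compounds cannot be ranked. No independent data bear on this result.

Compound 3 brings in the ring and the carbonyl together, so a plain oxan-3-ylmethyl group would be needed to tell the two apart. From the compounds shown here alone, whether an amine or a carboxylic acid on this oxygen would carry the number beyond the scatter also stays open.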